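This account rests on a few compounds, and the source may have more. Where it says the series, first, only, none or still open, it means among the compounds named here.

Compound 1 `C=CCn1c(=O)/c(=C\c2ccc(F)c(Br)c2)[nH]c(=O)/c1=C\c1ccccc1OC` was tested in a functional assay on HL-60 cells (Homo sapiens) for cytotoxicity, read by CCK-8 assay, with a stated time of 72 h (on this read-out higher numbers stand for weaker inhibition and lower numbers for stronger inhibition), and, in that assay, compound 1 is recorded as "not active" (no number reported), with no single number behind the entry. It is not alone in this: compound 3 `COc1ccccc1/C=c1/[nH]c(=O)/c(=C\c2cccc(Cl)c2Cl)[nH]c1=O` is also recorded in this assay as "not active" (no number reported). Against these two stands compound 2 `COc1ccccc1/C=c1/[nH]c(=O)/c(=C\c2nc[nH]c2C(C)(C)C)[nH]c1=O`, which in this assay gives 70 nM, the only numerical value in the set. Compound 1 therefore sits among the entries without a number, and nothing in the set places it on a scale.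

Compound 4 `C=CCn1c(=O)/c(=C\c2ccc(Cl)c(Cl)c2)[nH]c(=O)/c1=C\c1ccccc1OC` differs from compound 1 in one place: 3,4-dichlorophenyl in place of 3-bromo-4-fluorophenyl on a double-bonded chain carbon bound to an aromatic carbon. Among the compounds with values here, no measured pair shows a change of this kind, so no size or direction of step can be read from the data. Because compound 1 is recorded as "not active" (no number reported) and compound 3, which also carries a dichlorophenyl group, is recorded as "not active" (no number reported), the expectation is that compound 4 remains weak, and most likely is again reported without a number. If a number does come out, compound 4 is estimated at about 20000 nM, in the range from 3000 nM to 100000 nM.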

Compound 4, half-maximal inhibitory concentration: "not active" (no number reported)
No number was reported for compound 4; there is nothing to compare the estimate with.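

Compound 1 and compound 4 are both entries without a number in this assay, and no step can be read between them. Nothing available bears on this result. The compounds shown leave open whether any other group at this place would give a measurable value.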